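A few compounds are considered here, and "the series" means these few. Any claim that something is new, unique, unknown or untested is made for them only; others in the source may bear on it.

Compound 1 `CC1(c2ccc(NC(c3ccc(F)cc3)c3nnnn3C(C)(C)C)cc2)NC(=O)c2ccccc2N1` was not measured in an ADME assay on J774.A1 cells (Mus musculus) for cytotoxicity, read by MTT assay, with a stated time of 72 h; on this read-out higher numbers stand for lower toxicity in this test and lower numbers for higher toxicity in this test: there compound 1 gives "not determined" (no result reported), so no number for it is known, and it enters this step without a value of its own. Among the measured compounds shown here, the only measured relative is compound 2 `CC(C)(C)Nc1nc(Nc2ccc(C3(C)NC(=O)c4ccccc4N3)cc2)nc(NC(C)(C)C)n1`, which shares the core of compound 1 but differs from it elsewhere in the structure; in this assay compound 2 gives 60700 nM. Compound 3 `COc1ccc(C(Nc2ccc(C3(C)NC(=O)c4ccccc4N3)cc2)c2nnnn2C(C)(C)C)cc1` is obtained from compound 1 by a single change: methoxy in place of fluoro on an aromatic carbon. For the measured compounds named here, no measured pair shows this change, so the size of the step in this assay cannot be read from the data; a shift either way that stays within the usual scatter is as plausible as none at all, and compound 2 is the only hint of where compounds of this core tend to fall. In this assay compound 3 is expected at about 50000 nM, with a range from 15000 nM to 150000 nM.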

Compound 3, half-maximal cytotoxic concentration: > 400000 nM
Compound 3: only a limit was reported (the forecaster's own chance of this, stated with the estimate: 30%); middle value at least 8.0-fold (0.90 log units) from the limit.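

In this assay compound 3 gives > 400000 nM, a limit of the assay and not a number. Among the compounds shown here, with no number for compound 1, no step between compound 1 and compound 3 can be read. The compounds shown leave open how large an effect, if any, the change from 4-fluorophenyl to 4-methoxyphenyl has on this read-out.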